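A few compounds are considered here, and "the series" means these few. Any claim that something is new, unique, unknown or untested is made for them only; others in the source may bear on it.

Among the compounds with values here, the three compounds measured so far share one core and differ only in the groups attached to it. Compound 1 `CONc1nc(N)nc2c1ncn2[C@@H]1O[C@H](CO)[C@@H](O)[C@@]1(C)O`, compound 2 `COc1nc(Cl)nc2c1ncn2[C@@H]1O[C@H](CO)[C@@H](O)[C@@]1(C)O` and compound 3 `COc1nc(ONC(=O)OCc2ccccc2)nc2c1ncn2[C@@H]1O[C@H](CO)[C@@H](O)[C@@]1(C)O` were each tested in an ADME assay on Vero cells (Chlorocebus sabaeus) for cytotoxicity, with a stated time of 3 days; a lower number here means that less compound is tolerated, a higher number that more compound is tolerated. In this assay compound 1 gives > 100000 nM, which is a limit of the assay and not a measured number. Compound 2 likewise reaches only the limit of > 100000 nM. Compound 3 also stops at a limit, > 100000 nM. Compound 3 therefore stands exactly where the other two stand, at the limit of > 100000 nM in this assay, at which 3 of the 3 values shown sit, and no number separates it from them.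

Compound 4 `COc1nc(O)nc2c1ncn2[C@@H]1O[C@H](CO)[C@@H](O)[C@@]1(C)O` has not been measured. Against compound 3 it shows (hydrogen in place of (benzyloxycarbonyl)amino on an oxygen on an aromatic ring), so a sizeable group is lost and only a hydroxyl remains on the shared core. Within the data shown here, since no step between measured compounds exists, there is nothing to scale from; with all three measured values sitting at the same limit, the step from compound 3 to compound 4 is expected to be a step that the limit leaves unreadable from compound 3 to compound 4, that is, nothing beyond the scatter. Compound 4 is accordingly estimated to give about 200000 nM in this assay, with a plausible range from 90000 nM to 1000000 nM, and most likely it will again be reported only as a limit.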

Compound 4, half-maximal cytotoxic concentration: > 100000 nM
Compound 4: only a limit was reported; the forecaster's own chance of this, stated with the estimate: 85%; the middle value is on the limit's open side.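

In this assay compound 4 gives > 100000 nM, which is a limit of the assay and not a measured number. The steps to compound 4 from compound 3 and from compound 2 therefore cannot be read. The compounds shown leave open at what concentration any of them would harm these cells, and how they differ, because all share one value: the limit of > 100000 nM in this assay, at which 4 of the 4 values shown sit.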